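This account rests on a few compounds, and the source may have more. Where it says the series, first, only, none or still open, it means among the compounds named here.

Measured compounds in the series:

Compound 1, `COc1ccc(C2=C(c3ccsc3)C(=O)N3CCCC3C2)cc1`, in a functional assay on HCT-116 cells (Homo sapiens) for cytotoxicity (a lower number here means a stronger inhibitor, a higher number a weaker inhibitor), gives 1500 nM.
Compound 2, `CSc1ccc(C2=C(c3ccncc3)C(=O)N3CCCC3C2)cc1`, in this assay gives 6000 nM.

Compound 2 carries the highest number of the two measured; its nearest neighbour is compound 1, whose number is lower by a margin beyond the usual scatter. For the measured compounds named here, compounds 1 and 2 differ in two places at once, so no single-change step is available from them.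

Compound 3, `CSc1ccc(C2=C(c3ccsc3)C(=O)N3CCCC3C2)cc1`, is the next compound, not yet measured in this assay. It differs from compound 2 by one change: thiophen-3-yl in place of pyridin-4-yl on a double-bonded ring carbon. Compound 3 therefore shares the thiophen-3-yl group of compound 1 and the 4-(methylsulfanyl)phenyl group of compound 2.

The step from compound 2 to compound 3 is expected to lower the number, by an amount at the edge of the scatter, estimated as a 2.1-fold lower number from compound 2 to compound 3 (0.33 log units; beyond the scatter). Compound 3 is accordingly estimated in this assay at 2800 nM, within a range from 900 nM to 8000 nM.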

Compound 3, half-maximal inhibitory concentration: 600 nM
Compound 3: middle estimate off by 4.7-fold (0.67 log units), on the high side; the measured number lies below the stated range.
By their numbers in this assay, from the lowest: compound 3; then compound 1; then compound 2.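

In this assay, the group on the double-bonded ring carbon now has a single-change reading: with the 4-(methylsulfanyl)phenyl group held, thiophen-3-yl in place of pyridin-4-yl gives a 10-fold lower number from compound 2 to compound 3 (1.00 log units; beyond the scatter). The aromatic substituent can also be read on its own: with thiophen-3-yl held, methylsulfanyl in place of methoxy on an aromatic carbon gives a 2.5-fold lower number from compound 1 to compound 3 (0.40 log units; beyond the scatter), so both steps lie beyond the scatter and both lead to the lower number of compound 3. Nothing available explains either step.

Going by these compounds, it remains open whether the lower number is particular to thiophen-3-yl or also appears with a plain phenyl or a furan-3-yl ring at this position. Also open, on these data alone, is whether a longer chain on the sulfur, such as ethylsulfanyl, continues the step seen with methylsulfanyl.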